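The source may hold more compounds than are shown below. What is called first, only, known or untested is meant among the compounds shown, and "the series" means these compounds.

Measured so far:
Compound 1 `O=c1[nH]c2ccccc2cc1/C=N/O`: 31800 nM
Compound 2 `CCCC/N=C/c1cc2cc(C)ccc2[nH]c1=O`: 43300 nM

In a functional assay, read by spectrophotometry, with a stated time of 3 min (a lower number here means a stronger inhibitor, a higher number a weaker inhibitor), compound 1 gives 31800 nM. In this assay compound 2 gives 43300 nM, a number that sits within the usual scatter of the number for compound 1, so the two cannot be told apart. Compound 3 `CCCC/N=C/c1cc2ccccc2[nH]c1=O` differs from compound 2 in one place: hydrogen in place of methyl on an aromatic carbon. Within the data shown here, no measured pair here shows what this change does, so a small step is expected, with no clear direction and none beyond the scatter. For compound 3 the estimate is 40000 nM, with a range from 15000 nM to 110000 nM. The expected step of a 1.1-fold lower number from compound 2 to compound 3 (0.03 log units; within the scatter) stays within the scatter.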

Compound 3, half-maximal inhibitory concentration: 1810000 nM
Compound 3: the middle estimate sits 45-fold (1.66 log units) below what was measured; measured number outside the range, above it.
By their numbers in this assay, from the lowest: compounds 1 and 2 (each within the scatter of the next); then compound 3.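

In this assay, among these compounds, the methyl on the aromatic carbon matters far more than the earlier compounds could show: replacing it with hydrogen gives a 42-fold higher number from compound 2 to compound 3 (1.62 log units; beyond the scatter). With hydrogen on that carbon, the group on the double-bonded nitrogen also counts, as butyl in place of hydroxy gives a 57-fold higher number from compound 1 to compound 3 (1.76 log units; beyond the scatter). Nothing available explains why either change has so large an effect. From the compounds shown here alone, whether ethyl or chlorine on that aromatic carbon would match methyl remains open. So does how a shorter chain than butyl on the double-bonded nitrogen would behave.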